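Benzimidazole amide series: ethyl to cyclopropyl on the core

The source may report more compounds than this note shows. Statements on the series, on what has been measured and on what is new or still open speak of the compounds shown alone.

Three measured compounds frame the series. Compound 2 `CCc1nc2c(C(=O)NCC3CCN(CC(O)CN4CCN(S(C)(=O)=O)CC4)CC3)cccc2[nH]1` gives 0.501 nM in an assay on isolated protein for binding affinity to 5-hydroxytryptamine receptor 4 (Homo sapiens) (a lower number here means a stronger inhibitor, a higher number a weaker inhibitor), the lowest of the three numbers. Compound 1 `CC(=O)N1CCN(CCN2CCC(CNC(=O)c3cccc4[nH]c(C(C)C)nc34)CC2)CC1`, with a different linker and an acetylpiperazine, gives 5.01 nM in this assay, a step up from compound 2 beyond the scatter. Compound 3 `CS(=O)(=O)N1CCN(CC(O)CN2CCC(NC(=O)c3cccc4[nH]cnc34)CC2)CC1`, with no substituent on the aromatic carbon of the five-membered ring and the amide set directly on the piperidine, gives 251 nM in this assay, the highest number of the three and well beyond the scatter from compound 2. For the measured compounds named here, no pair among the measured compounds differs in a single place, so no isolated step size is on hand.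

Compound 4 `CS(=O)(=O)N1CCN(CC(O)CN2CCC(CNC(=O)c3cccc4[nH]c(C5CC5)nc34)CC2)CC1` is the next compound to be measured and differs from compound 2 in one place: cyclopropyl in place of ethyl on an aromatic carbon. The linker with the hydroxy group, the methanesulfonyl piperazine and the amide are kept.

Going by the values given here, with no matching step available, the expectation rests on the closeness of the two groups as named. The step is expected to stay within the scatter, with a 1.2-fold higher number from compound 2 to compound 4 (0.08 log units; within the scatter) as the estimated change. Compound 4 is expected to give 0.6 nM in this assay, in a range from 0.2 nM to 2 nM.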

Compound 4, inhibition constant: 0.501 nM
Compound 4: middle estimate off by 1.2-fold (0.08 log units), on the high side; the range from low to high includes it.
By their numbers in this assay, from the lowest: compounds 2 and 4 (each within the scatter of the next); then compound 1; then compound 3.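

In this assay the series now has its first step in a single place: cyclopropyl in place of ethyl on the aromatic carbon between two ring nitrogen atoms shows no change at the digits printed from compound 2 to compound 4 (within the scatter). This position therefore accepts a three-membered non-aromatic ring of carbon only in place of a group with no ring, with the hydroxy linker, the methanesulfonyl piperazine and the amide held fixed, and the read-out does not separate the two groups. No measurement on hand bears on why ethyl and cyclopropyl read alike here.

The compounds shown do not settle how far this position stretches: a longer chain such as n-butyl, a phenyl ring, an amine or a carboxylic acid on the same carbon would test whether the flat response continues or ends. Also open, on these data alone, is whether the swap of ethyl for cyclopropyl reads the same on a different side chain, for instance with an acetylpiperazine in place of the methanesulfonyl piperazine.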